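Swapping the Side Chain of Compound 1

The source may hold more compounds than are shown below. What is called first, only, known or untested is meant among the compounds shown, and "the series" means these compounds.

Measured compounds in a functional assay on the whole organism (Tail, strain ICR) with Mus musculus as the target, in the tail flick test, with a stated time of 120 min, at a dose of 25 umol/kg by the oral route; a higher number here means a stronger effect of the compound at the dose given, a lower number a weaker effect:
- compound 1, `CSCC[C@H](NC(=O)CN(c1nc(Cl)nc2[nH]cnc12)C1CC1)C(=O)OCc1ccccc1`: compound 1 gives 31.6%
- compound 2, `CSCC[C@H](NC(=O)CN(c1nc(Cl)nc2[nH]cnc12)C1CC1)C(=O)O`: compound 2 gives 5.67%
- compound 3, `O=C(CN(c1ncnc2c1ncn2C1CCCCO1)C1CC1)N[C@@H](CCC(=O)OCc1ccccc1)C(=O)OCc1ccccc1`: compound 3 gives 20.7%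

Compound 1 stands highest of the three; compound 3 is lower by more than the scatter, and compound 2 is lower still, by a number 25.9 percentage points lower from compound 1 to compound 2 (beyond the scatter). Compound 4, `C[C@@H](O)[C@H](NC(=O)CN(c1nc(Cl)nc2[nH]cnc12)C1CC1)C(=O)OCc1ccccc1`, differs from compound 1 in one place: 1-hydroxyethyl in place of 2-(methylsulfanyl)ethyl on a saturated chain carbon bound to an amide-type nitrogen and a carbonyl carbon. Among the compounds with values here, no measured step touches this position; the only single-point step, a number 25.9 percentage points lower from compound 1 to compound 2 (beyond the scatter), concerns the ester end and gives no guide. The expectation is therefore a modest decline or none beyond the scatter, a number 9.6 percentage points lower from compound 1 to compound 4 (within the scatter). Compound 4 is estimated at 22%, within 5% to 40%.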

Compound 4, a percentage reported as activity, at one dose (the size of the read-out at that dose, not a potency): 30.7%
Compound 4: the middle estimate sits 8.7 percentage points below what was measured; measured number inside the range.
By their numbers in this assay, from the lowest: compound 2; then compounds 3, 4 and 1 (each within the scatter of the next, the first and the last beyond it).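

At the saturated chain carbon bound to an amide-type nitrogen and a carbonyl carbon, 1-hydroxyethyl can take the place of 2-(methylsulfanyl)ethyl, with a number 0.9 percentage points lower from compound 1 to compound 4 (within the scatter) in this assay. The sulfur of the leaving chain is thus not required to hold this read-out at this dose, and the added hydrogen-bond donor does not change it beyond the scatter. Nothing available explains why the two chains read alike.

As far as these compounds go, it remains open how an amine, a carboxylic acid or a longer chain would read at this position. From the compounds shown here alone, the role of the defined stereocentre in 1-hydroxyethyl is also open.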